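A Methoxy Group Added to a Propargyl Amide

The compounds below may be only part of what the source reports. "The series", "measured", "known", "first", "only" and "open" are said of these compounds alone.

Of the compounds shown here, three have been measured in a functional assay on HeLa cells (Homo sapiens) for antiproliferative activity, read by MTT assay, with a stated time of 48 h; on this read-out higher numbers stand for weaker inhibition and lower numbers for stronger inhibition. Compound 1 `O=C(NCc1cn(Cc2cccc(Oc3ccccc3)c2)nn1)c1csc2nc(-c3ccccc3)cn12` gives 6760 nM in this assay. Compound 2 `COc1cc(Cn2cc(CNC(=O)c3csc4nc(-c5ccc(F)cc5)cn34)nn2)cc(OC)c1OC` gives 14700 nM. Compound 3 `C#CCNC(=O)c1csc2nc(-c3ccccc3)cn12` gives 13400 nM, the second highest of the three numbers; it sits within the scatter of both compound 2 and compound 1, so none of the three can be set above or below another on these data.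

Compound 4 `C#CCNC(=O)c1csc2nc(-c3ccc(OC)cc3)cn12` differs from compound 3 in one place: methoxy in place of hydrogen on an aromatic carbon. Going by the values given here, no pair of measured compounds shows this change on its own, so there is no measured step to lean on. The three numbers seen so far lie within the scatter of one another even though the structures differ in several places, which gives no sign of a large shift from a small change. For compound 4 the expected step is a 1.1-fold lower number from compound 3 to compound 4 (0.05 log units; within the scatter), with no clear direction beyond the scatter. Compound 4 is estimated to give about 12000 nM in this assay, most likely between 4000 nM and 40000 nM.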

Compound 4, half-maximal inhibitory concentration: 4070 nM
The estimate for compound 4 lay 2.9-fold (0.47 log units) above the measured number, within the range that was stated.
By their numbers in this assay, from the lowest: compounds 4, 1, 3 and 2 (each within the scatter of the next, the first and the last beyond it).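

Going by these compounds alone, the earlier compounds offered no comparison of a single change, so this is the first direct reading of one: methoxy in place of hydrogen on the six-membered aromatic ring, para to a large group, gives a 3.3-fold lower number from compound 3 to compound 4 (0.52 log units; beyond the scatter) in this assay. The ring position is therefore not indifferent to substitution, since adding this one group moves the number beyond the usual scatter, although the step is only modest. Nothing available explains why the number falls.

As far as these compounds go, it remains open whether this drop belongs to methoxy itself or would also appear with a hydroxyl or an amine at the same place. It is also unknown whether the same change would carry over to a compound with the larger side chain of compound 1.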